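The source may hold more compounds than are shown below. What is called first, only, known or untested is meant among the compounds shown, and "the series" means these compounds.

Of the compounds shown here, three have been tested in an assay on isolated protein for binding affinity to Alpha-1A adrenergic receptor (Rattus norvegicus), read by radioligand binding; on this read-out higher numbers stand for weaker inhibition and lower numbers for stronger inhibition. Compound 1 `CCS(=O)(=O)Nc1cccc(C2CCNC2)c1` gives 501 nM in this assay, the second highest of the three numbers. Its nearest neighbour is compound 3 `CS(=O)(=O)Nc1cccc2c1OCCC2c1c[nH]cn1`, which gives 479 nM, a gap within the usual scatter. Compound 2 `CCS(=O)(=O)Nc1cccc2c1CCCC2CNC` gives 1380 nM, a higher number than compound 1 by a gap beyond the scatter. Compound 4 `CCS(=O)(=O)Nc1cccc(Sc2c[nH]cn2)c1` has not yet been measured. It differs from compound 1 in one place: (1H-imidazol-4-yl)sulfanyl in place of pyrrolidin-3-yl on an aromatic carbon. Going by the values given here, no measured pair shows this change, so the size of the step is uncertain; on balance compound 4 is expected to remain in the range of compound 1, with the step from compound 1 to compound 4 estimated as a 1.0-fold lower number from compound 1 to compound 4 (0.00 log units; within the scatter). Compound 4 is therefore estimated at 500 nM, between 150 nM and 1700 nM.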

Compound 4, inhibition constant: < 10000 nM
Compound 4: a limit, no number; the forecaster's own chance of this, stated with the estimate: 5%; the middle value does not contradict the limit.
By their numbers in this assay, from the lowest: compounds 3 and 1 (each within the scatter of the next); then compound 2.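

Going by these compounds alone, for compound 4 the result, < 10000 nM, is a limit and not a number, so no step from compound 1 to compound 4 can be read. Open remains how far (1H-imidazol-4-yl)sulfanyl in place of pyrrolidin-3-yl shifts the number in this assay.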